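Repositioning the methyl groups on the anilide of compound 1

A few compounds are considered here, and "the series" means these few. Any claim that something is new, unique, unknown or untested is made for them only; others in the source may bear on it.

Measured compounds:
compound 1 `Cc1cccc(C)c1NC(=O)/C=C/C(=O)N1C/C(=C\c2ccccc2)C(=O)/C(=C/c2ccccc2)C1` — 22000 nM
compound 2 `O=C(/C=C/C(=O)N1C/C(=C\c2ccc([N+](=O)[O-])cc2)C(=O)/C(=C/c2ccc([N+](=O)[O-])cc2)C1)Nc1ccc([N+](=O)[O-])cc1` — 1000 nM
compound 3 `O=C(/C=C/C(=O)N1C/C(=C\c2ccc([N+](=O)[O-])cc2)C(=O)/C(=C/c2ccc([N+](=O)[O-])cc2)C1)Nc1ccc(Cl)cc1` — 3600 nM

All three compounds were tested in a functional assay on L1210 cells (Mus musculus) for cytotoxicity; a higher number here means a weaker inhibitor, a lower number a stronger inhibitor. Compound 1 `Cc1cccc(C)c1NC(=O)/C=C/C(=O)N1C/C(=C\c2ccccc2)C(=O)/C(=C/c2ccccc2)C1` gives 22000 nM, the highest of the three numbers; the nearest is compound 3, and the furthest is compound 2. For the measured compounds named here, the one step that can be read between single-point changes is the one from compound 2 to compound 3, a 3.6-fold higher number from compound 2 to compound 3 (0.56 log units; beyond the scatter), a chloro in place of a nitro on the aromatic carbon of the anilide ring.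

Compound 4 `Cc1ccc(NC(=O)/C=C/C(=O)N2C/C(=C\c3ccccc3)C(=O)/C(=C/c3ccccc3)C2)cc1C` has not yet been measured. It differs from compound 1 by 3,4-dimethylphenyl in place of 2,6-dimethylphenyl on an amide-type nitrogen. Going by the values given here, no measured pair speaks to a shift of two methyl groups around the anilide ring; the step from compound 2 to compound 3 only shows that changing what sits on that ring can move this assay modestly. With nothing more to go on, the author expects compound 4 to stay close to compound 1, a step of a 1.2-fold lower number from compound 1 to compound 4 (0.09 log units; within the scatter) that is not expected to exceed the scatter. Compound 4 is therefore estimated at 18000 nM, within a range from 7000 nM to 45000 nM.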

Compound 4, half-maximal inhibitory concentration: 31000 nM
Compound 4: middle estimate off by 1.7-fold (0.24 log units), on the low side; measured number inside the range.
By their numbers in this assay, from the lowest: compound 2; then compound 3; then compounds 1 and 4 (each within the scatter of the next).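

In this assay, 3,4-dimethylphenyl in place of 2,6-dimethylphenyl on the amide-type nitrogen gives a 1.4-fold higher number from compound 1 to compound 4 (0.15 log units; within the scatter), so compound 1 and compound 4 cannot be told apart in this assay. For the compounds shown here, this is the first reading of a rearrangement that keeps the same atoms on the anilide ring: in this pair, the placement of the two methyl groups leaves the number within the scatter, whereas the step from compound 2 to compound 3, which exchanged one group for another on a different background, went beyond it. No measurement is available that would account for this result.

Compound 2 and compound 3 each differ from compound 1 in more than one place, so these compounds do not show whether exchanging nitro and chloro on the anilide ring would have any comparable effect on the core of compound 1. As far as these compounds go, it also remains open whether an amine, a carboxylic acid or a longer chain such as butyl on this ring, in place of the methyl groups, would move the number beyond the scatter.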